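Adding a Fluorine to the Aryl Group of Compound 3

The compounds below may be only part of what the source reports. "The series", "measured", "known", "first", "only" and "open" are said of these compounds alone.

Of the compounds shown here, three have been tested in a functional assay on CHO cells for antagonist activity at Orexin/Hypocretin receptor type 1 (Homo sapiens), read by FLIPR and calcium flux; a lower number here means a stronger inhibitor, a higher number a weaker inhibitor. Compound 1 `CCc1nc(Cl)c2n1CCN([C@@H](C(=O)NC)c1ccccc1)[C@H]2CCc1ccc(C(F)(F)F)c(F)c1F` gives 17 nM, compound 2 `CCc1nc(Cl)c2n1CCN([C@@H](C(=O)NC)c1ccccc1)[C@H]2CCc1ccc(F)c(F)c1F` gives 30 nM, and compound 3 `CNC(=O)[C@@H](c1ccccc1)N1CCn2c(C3CC3)nc(Cl)c2[C@@H]1CCc1ccc(C(F)(F)F)cc1` gives 30 nM. Compound 3 thus sits level with compound 2, the two together giving the highest numbers of the three, while its gap to compound 1 lies inside the scatter. For the measured compounds named here, the one step between close neighbours, a 1.8-fold higher number from compound 1 to compound 2 (0.25 log units; within the scatter), also stays within the scatter.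

Compound 4 `CNC(=O)[C@@H](c1ccccc1)N1CCn2c(C3CC3)nc(Cl)c2[C@@H]1CCc1ccc(C(F)(F)F)cc1F` differs from compound 3 in one place: fluoro in place of hydrogen on an aromatic carbon. Going by the values given here, no measured pair shows this exact change; the only measured step swaps a trifluoromethyl for a fluoro group and moves the number very little, so nothing in hand points to a large shift. Compound 4 is therefore expected to give a number close to that of compound 3, a step of a 1.2-fold lower number from compound 3 to compound 4 (0.08 log units; within the scatter) in this assay. The estimate for compound 4 is 25 nM, with an expected range from 10 nM to 60 nM.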

Compound 4, half-maximal inhibitory concentration: 94 nM
Estimate against measurement, compound 4: 3.8-fold (0.58 log units) below, and the stated range ends below it.
By their numbers in this assay, from the lowest: compounds 1, 2 and 3 (each within the scatter of the next); then compound 4.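

In this assay, the 4-(trifluoromethyl)phenyl group of compound 3 proves sensitive to one added atom: placing a fluoro group on this aromatic carbon, ortho to a large group and meta to the trifluoromethyl group, gives a 3.1-fold higher number from compound 3 to compound 4 (0.50 log units; beyond the scatter) and makes compound 4 the weaker inhibitor of this pair. For the compounds shown here, this is the first step here that goes beyond the scatter, so even the smallest change on this ring can be read in this assay, and here it costs activity. Nothing at hand says why the number rises.

On these data alone, it remains open whether this loss belongs to fluoro itself or to any group at this carbon, which a chlorine, a methyl or a methoxy group there would help to settle. Also open, as far as these compounds go, is how a fluoro group on the other carbons of this ring would behave when the rest of compound 3 stays unchanged.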